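Ring nitrogen methylation in a weakly cytotoxic series

The source may hold more compounds than are shown below. What is called first, only, known or untested is meant among the compounds shown, and "the series" means these compounds.

The shared core carries an anilino group and is read in a functional assay on T47D cells (Homo sapiens) for cytotoxicity, read by MTT assay, with a stated time of 48 h; a higher number here means a weaker inhibitor, a lower number a stronger inhibitor. Compound 1 `O=C1CNc2nc(Nc3ccccc3)ncc2N1` gives 85400 nM in this assay. Compound 2 `O=C1CNc2nc(Nc3ccc(Cl)cc3)ncc2N1` gives 29300 nM in this assay, and the step of a 2.9-fold lower number from compound 1 to compound 2 (0.46 log units; beyond the scatter) is the only move beyond the scatter seen so far. Compound 3 `COc1cccc(Nc2ncc3c(n2)NCC(=O)N3)c1` sits at the limit of this assay, > 100000 nM, which is a limit and not a number. The step of an at least 1.1-fold higher number from compound 1 to compound 3 (0.06 log units; that floor lies within the scatter) stays within the scatter, and the limit of > 100000 nM in this assay, at which 1 of the 3 values shown sits, marks where compound 3 stands.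

Compound 4 `COc1cccc(Nc2ncc3c(n2)N(C)CC(=O)N3)c1` differs from compound 3 by methyl in place of hydrogen on a nitrogen on an aromatic ring in a ring. Neither measured step touches this place: the change from compound 1 to compound 2 and the change from compound 1 to compound 3 both alter the aromatic ring of the anilino group, not the ring nitrogen of the core. Going by the values given here, no measured step therefore bears on this change, and no movement beyond the scatter is expected in this assay. Compound 4 is expected to sit near the same limit, with the expected step being a number no higher from compound 3 to compound 4 (the limit leaves the size open). Compound 4 is estimated at 100000 nM, with a range from 40000 nM to 300000 nM.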

Compound 4, half-maximal inhibitory concentration: > 100000 nM
Compound 4: no number, only a limit (the forecaster's own chance of this, stated with the estimate: 70%); the middle value sits exactly at the limit.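

In this assay compound 4 gives > 100000 nM, a limit and not a number. Going by these compounds alone, with compound 3 also at a limit, no step between compound 3 and compound 4 can be read: the limit of > 100000 nM in this assay, at which 2 of the 4 values shown sit. The compounds shown leave open whether methyl in place of hydrogen on this nitrogen shifts the value of any compound with a readable number in this assay.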